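Working notes on a small cytotoxicity series

The source may report more compounds than this note shows. Statements on the series, on what has been measured and on what is new or still open speak of the compounds shown alone.

Compound 1 `Cc1ccccc1OCC(=O)Nc1nc(-c2ccc(Br)cc2)cs1` gives 44500 nM in a functional assay on MDA-MB-468 cells (Homo sapiens) for cytotoxicity, read by trypan blue exclusion, with a stated time of 48 h; on this read-out higher numbers stand for weaker inhibition and lower numbers for stronger inhibition. Compound 2 `O=C(COc1ccc(F)cc1F)Nc1nc(-c2ccc(Br)cc2)cs1` differs from compound 1 by 2,4-difluorophenyl in place of 2-methylphenyl on an oxygen on a saturated carbon; in this assay compound 2 gives 44700 nM, the step being a 1.0-fold higher number from compound 1 to compound 2 (0.00 log units; within the scatter). Compound 3 `Cc1ccccc1OCC(=O)Nc1nc(-c2ccc(Cl)cc2)cs1` differs from compound 1 by chloro in place of bromo on an aromatic carbon, and in this assay compound 3 gives 52100 nM, with the step of a 1.2-fold higher number from compound 1 to compound 3 (0.07 log units; within the scatter). Compound 4 `O=C(COc1ccc(F)cc1F)Nc1nc(-c2ccc(Cl)cc2)cs1` is not yet measured; it differs from compound 3 by 2,4-difluorophenyl in place of 2-methylphenyl on an oxygen on a saturated carbon, the same change as between compound 1 and compound 2, made on the core of compound 3. Among the measured compounds shown here, because the one measured instance of that change read a 1.0-fold higher number from compound 1 to compound 2 (0.00 log units; within the scatter), the expected step is a 1.0-fold lower number from compound 3 to compound 4 (0.00 log units; within the scatter). Compound 4 is accordingly estimated at 52000 nM in this assay, expected to lie between 26000 nM and 104000 nM. This rests on a single measured pair.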

Compound 4, half-maximal inhibitory concentration: 32300 nM
For compound 4 the middle estimate is 1.6-fold (0.21 log units) above the measured one, within the range that was stated.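

The change to 2,4-difluorophenyl in place of 2-methylphenyl reads a 1.6-fold lower number from compound 3 to compound 4 (0.21 log units; within the scatter) in this assay, and its two instances do not differ: the same change on two cores in this assay, a 1.0-fold higher number (0.00 log units; within the scatter) from compound 1 to compound 2 and a 1.6-fold lower number (0.21 log units; within the scatter) from compound 3 to compound 4, 1.6-fold (0.21 log units) apart, within the scatter of two such steps. Chloro in place of bromo reads a 1.4-fold lower number from compound 2 to compound 4 (0.14 log units; within the scatter), and it also holds across the two cores: the same change on two cores in this assay, a 1.2-fold higher number (0.07 log units; within the scatter) from compound 1 to compound 3 and a 1.4-fold lower number (0.14 log units; within the scatter) from compound 2 to compound 4, 1.6-fold (0.21 log units) apart, within the scatter of two such steps. This shows that neither change moves the read-out beyond the scatter on either core, but with every step inside the scatter it does not show whether either change has any real effect that carries from one core to another.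

Still open, on these data alone, is whether an amine or a carboxylic acid in place of chloro or bromo would move the read-out beyond the scatter. The same question stands for a longer chain between the oxygen and the carbonyl.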